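The compounds below may be only part of what the source reports. "The series", "measured", "known", "first", "only" and "open" are said of these compounds alone.

Measured compounds:
- compound 1 `NC(=O)N(O)C1CCc2cccc(Oc3ccccc3)c21`: 5600 nM
- compound 2 `COc1ccc2c(c1)CCCC2N(O)C(N)=O`: 48000 nM

In an assay on isolated protein for inhibition of Polyunsaturated fatty acid 5-lipoxygenase (Rattus norvegicus) (on this read-out higher numbers stand for weaker inhibition and lower numbers for stronger inhibition), compound 2 gives 48000 nM, the highest of the two numbers measured. Its nearest neighbour, compound 1, gives 5600 nM in this assay, a lower number and therefore a stronger inhibitor; the gap between the two lies beyond the usual scatter. The two compounds differ in more than one place, so the gap cannot be pinned to a single change.

Compound 3 `NC(=O)N(O)C1CCCc2ccccc21` has not yet been measured. It differs from compound 2 by hydrogen in place of methoxy on an aromatic carbon. Among the compounds with values here, no measured pair in this set isolates this change, so the step cannot be read from the data. The expected step from compound 2 to compound 3 is a 1.6-fold lower number from compound 2 to compound 3 (0.20 log units; within the scatter), small and close to the scatter, if anything towards a lower number. Compound 3 is therefore estimated at 30000 nM in this assay, within a range from 8000 nM to 120000 nM.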

Compound 3, half-maximal inhibitory concentration: 29000 nM
Compound 3: middle estimate off by 1.0-fold (0.01 log units), on the high side; the range from low to high includes it.
By their numbers in this assay, from the lowest: compound 1; then compounds 3 and 2 (each within the scatter of the next).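

Within the data shown here, this is the first pair in the set that differs in one place only, so the effect of this change can now be read directly. In this assay, putting hydrogen in place of methoxy on this aromatic carbon gives a 1.7-fold lower number from compound 2 to compound 3 (0.22 log units; within the scatter). The two compounds cannot be told apart on this read-out, so the methoxy group is not needed for the inhibition seen with compound 2, and no measurement shown here offers an explanation for this result.

As far as these compounds go, it remains open whether an amine or a carboxylic acid on this same aromatic carbon would move the number beyond the scatter. Compound 1 differs from both other compounds in more than one place, so those gaps cannot be assigned to any single change.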